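The source may report more compounds than this note shows. Statements on the series, on what has been measured and on what is new or still open speak of the compounds shown alone.

Two compounds were measured in an assay on isolated protein for inhibition of hexokinase-2 (Rattus norvegicus), with a stated time of 6 h, tested at 10 mM; a lower number here means less inhibition, a higher number more inhibition at the concentration tested (going by the name of the read-out):

compound 1 `O=C(CI)NCCCCCCCCNc1ncnc2c1ncn2[C@@H]1O[C@H](COP(=O)(O)OP(=O)(O)OP(=O)(O)O)[C@@H](O)[C@H]1O`: 41%
compound 2 `CN(CCCCN(C)c1ncnc2c1ncn2[C@@H]1O[C@H](COP(=O)(O)OP(=O)(O)OP(=O)(O)O)[C@@H](O)[C@H]1O)C(=O)CCCCCNC(=O)CI`: 0%

Compound 1 holds the higher of the two numbers; compound 2 lies well below it, by a gap beyond the usual scatter. Compound 3 `CC(=O)NCCCCCCCCNc1ncnc2c1ncn2[C@@H]1O[C@H](COP(=O)(O)OP(=O)(O)OP(=O)(O)O)[C@@H](O)[C@H]1O` has not yet been measured. It differs from compound 1 in one place: hydrogen in place of iodo on a saturated chain carbon bound to a carbonyl carbon. Among the measured compounds shown here, no step between measured compounds covers this change, so its size must be judged from compound 1 alone, whose inhibition of 41% in this assay is the only anchor. The expectation is that the step from compound 1 to compound 3 runs downward, by more than the scatter, and is estimated at a number 31 percentage points lower from compound 1 to compound 3 (beyond the scatter). Compound 3 is therefore expected to give about 10% in this assay, with a range from 0% to 30%.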

Compound 3, a percentage reported as inhibition, at one concentration (the size of the read-out at that concentration, not a potency): -12%
Compound 3: middle estimate off by 22 percentage points, on the high side; measured number outside the range, below it.
By their numbers in this assay, from the lowest: compound 3; then compound 2; then compound 1.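

In this assay, putting hydrogen in place of iodo on the saturated chain carbon bound to a carbonyl carbon gives a number 53 percentage points lower from compound 1 to compound 3 (beyond the scatter), the first step read at this position. Among the compounds shown here, with ((iodomethyl)carbonyl)amino changed to acetamido and the rest of the structure kept, the inhibition does not persist: compound 3 gives -12%, so within this pair, the inhibition at the concentration tested is seen only with iodo present. No measurement shown here accounts for the size of this step.

As far as these compounds go, it remains open whether chloro or bromo at this same place would retain the inhibition of compound 1, or whether an amine there would give a reading closer to that of compound 3. The compounds shown also leave open how a longer chain would affect the inhibition with iodo kept in place.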